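Reversing a linker: benzyloxy against phenoxymethyl on the carbonyl

This account rests on a few compounds, and the source may have more. Where it says the series, first, only, none or still open, it means among the compounds named here.

The measured compounds:
compound 1 `Nc1nc(N2CCN(C(=O)COc3ccc(Cl)cc3)CC2)c2nc(-c3ccc(F)cc3)sc2n1`, 490 nM;
compound 2 `Nc1nc(N2CCN(C(=O)OCc3ccccc3)CC2)c2nc(-c3ccc(F)cc3)sc2n1`, 4900 nM.

In a functional assay on cells (Lymphocyte, Homo sapiens) (on this read-out higher numbers stand for weaker inhibition and lower numbers for stronger inhibition), compound 2 gives the higher of the two numbers, its nearest neighbour being compound 1 at 490 nM. Going by the values given here, the one measured step, a 10-fold higher number from compound 1 to compound 2 (1.00 log units; beyond the scatter), joins these two compounds. Compound 3 `Nc1nc(N2CCN(C(=O)COc3ccccc3)CC2)c2nc(-c3ccc(F)cc3)sc2n1` is the next in line. It differs from compound 2 in that the same atoms are joined differently: phenoxymethyl in place of benzyloxy on a carbonyl carbon. This change undoes the connectivity part of the step from compound 1 to compound 2 while leaving out the chlorine that compound 1 carries, so only part of that step is expected to reverse. Compound 3 is therefore expected to land below compound 2 in this assay, with a step of a 4.1-fold lower number from compound 2 to compound 3 (0.61 log units; beyond the scatter), and an estimated value of 1200 nM, in the range 450 nM to 3200 nM.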

Compound 3, half-maximal inhibitory concentration: 90 nM
The estimate for compound 3 lay 13-fold (1.12 log units) above the measured number; measured number outside the range, below it.
By their numbers in this assay, from the lowest: compound 3; then compound 1; then compound 2.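

With the same atoms on the carbonyl carbon, connectivity alone has a large effect in this assay: phenoxymethyl in place of benzyloxy gives a 54-fold lower number from compound 2 to compound 3 (1.74 log units; beyond the scatter). The chlorine, which the earlier pair could not separate from the linker, also matters, as hydrogen in place of chloro on an aromatic carbon gives a 5.4-fold lower number from compound 1 to compound 3 (0.74 log units; beyond the scatter). The earlier step, a 10-fold higher number from compound 1 to compound 2 (1.00 log units; beyond the scatter), therefore combined two changes pulling in opposite directions, and it understated the effect of reversing the linker.

Nothing available explains why either change shifts the number so strongly. On these data alone, whether the linker oxygen can give way to an amine nitrogen, whether a longer chain is tolerated on the carbonyl, and whether a methyl or methoxy group on the phenyl ring behaves as chlorine does all remain open.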